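The compounds below may be only part of what the source reports. "The series", "measured", "known", "first", "only" and "open" are said of these compounds alone.

Compound 1 `FC(F)(F)c1ccc(NCCNc2ncc(-c3ncc[nH]3)c(-c3ccc(Cl)cc3Cl)n2)nc1`: > 0.5 h
Compound 2 `Nc1nc(NCCNc2ncc(-c3ncc[nH]3)c(-c3ccc(F)cc3F)n2)ccc1[N+](=O)[O-]`: > 0.5 h

Both compounds were tested in an ADME assay on microsomes from liver (Canis lupus familiaris) for metabolic stability; on this read-out lower numbers stand for a shorter-lived compound and higher numbers for a longer-lived compound. Compound 2 gives > 0.5 h, which is a limit of the assay and not a number. Compound 1 gives > 0.5 h, and this too is a limit. The whole record is therefore the limit of > 0.5 h in this assay, at which 2 of the 2 values shown sit: no exact half-life is known for either compound, and the two cannot be ranked.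

Compound 3 `Nc1nc(NCCNc2ncc(-c3ncc[nH]3)c(-c3ccc(F)cc3Br)n2)ccc1[N+](=O)[O-]` matches compound 2 except at one place: bromo in place of fluoro on an aromatic carbon. This is bromo in place of fluoro on an aromatic carbon, ortho to a large group and meta to a fluoro group, so 2,4-difluorophenyl becomes 2-bromo-4-fluorophenyl. Going by the values given here, no pair of measured compounds shows what this swap does in this assay, so no change beyond the scatter is expected. That expectation rests on compound 2, whose limit is > 0.5 h. The expected shift, a step that the limit leaves unreadable from compound 2 to compound 3, is only an estimate. Compound 3 is expected at 0.6 h, with an estimated range of 0.35 h to 1.2 h, and another limit would be no surprise.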

Compound 3, half-life: > 0.5 h
Compound 3: no number, only a limit; the forecaster's own chance of this, stated with the estimate: 80%; the middle value is on the limit's open side.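

No step can be read from compound 2 to compound 3, because each gives only a limit of the assay and no number: the limit of > 0.5 h in this assay, at which 3 of the 3 values shown sit.

The compounds shown leave open the actual half-life of each compound in this assay and whether bromo in place of fluoro on an aromatic carbon changes it at all.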